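Halogen swap on the triazole aryl of a kaurane-type scaffold

This account rests on a few compounds, and the source may have more. Where it says the series, first, only, none or still open, it means among the compounds named here.

Compound 2 `C=C1C(=O)[C@]23C[C@@]1(O)CC[C@H]2c1ccc(O)c(C)c1[C@@H]3Cn1cc(-c2ccc(Br)cc2)nn1` gives 1140 nM in a functional assay on A549 cells (Homo sapiens) for cytotoxicity, read by MTT assay, with a stated time of 4 days (on this read-out lower numbers stand for stronger inhibition and higher numbers for weaker inhibition), the lowest of the two numbers shown. Its tosylate compound 3 `C=C1C(=O)[C@]23C[C@@]1(O)CC[C@H]2c1ccc(OS(=O)(=O)c2ccc(C)cc2)c(C)c1[C@@H]3Cn1cc(-c2ccc(Br)cc2)nn1` gives 1630 nM in this assay, and the step of a 1.4-fold higher number from compound 2 to compound 3 (0.16 log units; within the scatter) lies within the scatter. Compound 1 `Cc1c(O)ccc2c1[C@H](Cn1cc(-c3ccc(Cl)cc3)nn1)[C@@]13CC(=O)[C@@](C)(CC[C@@H]21)C3` differs from compound 2 in several places at once. In this assay compound 1 reaches only a limit, > 20000 nM; the limit of > 20000 nM in this assay, at which 1 of the 3 values shown sits, gives no number to compare. Compound 4 `C=C1C(=O)[C@]23C[C@@]1(O)CC[C@H]2c1ccc(O)c(C)c1[C@@H]3Cn1cc(-c2ccc(F)cc2)nn1` differs from compound 2 by fluoro in place of bromo on an aromatic carbon. Within the data shown here, none of the measured steps concerns a change of the halogen on that ring, so no measured step bears directly on this one; the sole measured step, from compound 2 to compound 3, sits elsewhere and is within the scatter. In the absence of any evidence for the halogen change, compound 4 is expected to show a step of a 2.2-fold higher number from compound 2 to compound 4 (0.34 log units; beyond the scatter), a modest loss that may not exceed the scatter. Compound 4 is therefore estimated at 2500 nM, with a range from 800 nM to 8000 nM.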

Compound 4, half-maximal inhibitory concentration: 940 nM
The estimate for compound 4 lay 2.7-fold (0.42 log units) above the measured number; measured number inside the range.
By their numbers in this assay, from the lowest: compounds 4, 2 and 3 (each within the scatter of the next). At a limit, above all of these: compound 1.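

The halogen on this ring now has a measured step of its own: in this assay, going from 4-bromophenyl to 4-fluorophenyl gives a 1.2-fold lower number from compound 2 to compound 4 (0.08 log units; within the scatter). At this place, on an aromatic carbon para to a large group, bromo and fluoro therefore cannot be told apart on this read-out, so the value of compound 2 does not depend on bromo specifically. Nothing measured here gives a reason for this result.

The compounds shown leave open whether this holds only among halogens, since a group of another kind at the same place, such as an amine, a carboxylic acid or a methoxy group, could behave differently. From the compounds shown here alone, it also remains open what plain hydrogen at this place would give, and whether the same halogen swap would look alike on the tosylate compound 3.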